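Adding an Amino Group to a Well-Tolerated Oxime Ether

A few compounds are considered here, and "the series" means these few. Any claim that something is new, unique, unknown or untested is made for them only; others in the source may bear on it.

Compound 1 `CCO/N=C/c1ccc(OCCC(C)CCN2CCN(c3ccccc3)C2=O)cc1` is one of three close relatives tested for how much of each cultured human cells tolerate. In an ADME assay on RD cells (Homo sapiens) for cytotoxicity, read by MTT assay, with a stated time of 24 h (a higher number here means that more compound is tolerated, a lower number that less compound is tolerated), compound 1 gives only a limit, > 100000 nM. Compound 2 `CCO/N=C/c1ccc(OCCCCN2CCN(c3ccnc(N)c3)C2=O)cc1` likewise reaches only a limit in this assay, > 100000 nM. Compound 3 `CCO/N=C/c1ccc(OCC#CCN2CCN(c3ccnc(N)c3)C2=O)cc1` gives a limit too, > 100000 nM. Every value shown thus sits at the same point: the limit of > 100000 nM in this assay, at which 3 of the 3 values shown sit. Compound 4 `CCO/N=C/c1ccc(OCCC(C)CCN2CCN(c3cccc(N)c3)C2=O)cc1` has not yet been measured in this assay. It differs from compound 1 in one place: amino in place of hydrogen on an aromatic carbon. For the measured compounds named here, none of the measured compounds shows any change in tolerance, so no step beyond the scatter is expected. The step from compound 1 to compound 4 is estimated at a step that the limit leaves unreadable from compound 1 to compound 4. Compound 4 is expected to give about 150000 nM, within 60000 nM to 400000 nM, most likely again as a limit.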

Compound 4, half-maximal cytotoxic concentration: > 100000 nM
Compound 4: only a limit was reported (the forecaster's own chance of this, stated with the estimate: 80%); the middle value is on the limit's open side.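

Compound 1 and compound 4 each give only a limit in this assay, so no step between them can be read: the limit of > 100000 nM in this assay, at which 4 of the 4 values shown sit.

The compounds shown leave open how much of each the cells would tolerate, and whether the amino group alters that tolerance at all.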